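A fluorophenyl swap on the shared core

A few compounds are considered here, and "the series" means these few. Any claim that something is new, unique, unknown or untested is made for them only; others in the source may bear on it.

Compound 1, `COc1cc2c(Oc3ccc(NC(=O)c4nn(-c5ccc(F)cc5)c(=O)c5ccccc45)cc3F)ccnc2cc1OCCCN1CCN(C)CC1`: in a functional assay on MDA-MB-231 cells (Homo sapiens) for cytotoxicity, read by MTT assay, with a stated time of 72 h (a higher number here means a weaker inhibitor, a lower number a stronger inhibitor), compound 1 gives 460 nM.
Compound 2, `COc1cc2c(Oc3ccc(NC(=O)c4nn(-c5ccccc5F)c(=O)c5ccccc45)cc3F)ccnc2cc1OCCCN1CCN(C)CC1`: in this assay compound 2 gives 1050 nM.
Compound 3, `COc1cc2c(Oc3ccc(NC(=O)c4nn(-c5ccc(F)cc5)c(=O)c5ccccc45)cc3F)ccnc2cc1OCCCN1CCC(C)CC1`: in this assay compound 3 gives 660 nM.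

Compound 3 stands second highest of the three numbers; its gap to compound 1 and its gap to compound 2 both lie within the scatter of this assay, so no order among the three can be claimed.

Compound 4, `COc1cc2c(Oc3ccc(NC(=O)c4nn(-c5ccccc5Br)c(=O)c5ccccc45)cc3F)ccnc2cc1OCCCN1CCC(C)CC1`, differs from compound 3 by 2-bromophenyl in place of 4-fluorophenyl on an aromatic nitrogen. Among the compounds with values here, one measured step bears on this change: a 2.3-fold higher number from compound 1 to compound 2 (0.36 log units; beyond the scatter), a modest weakening when the fluorine on that ring was moved. Within the data shown here, no measured pair shows what bromine in place of fluorine does, so that part of the change is unanchored. The expectation is therefore a modest rise in the number, a 2.3-fold higher number from compound 3 to compound 4 (0.36 log units; beyond the scatter), carried by the measured step from compound 1 to compound 2, with a wide range to cover the untested bromine. Compound 4 is estimated at 1500 nM, between 600 nM and 4000 nM.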

Compound 4, half-maximal inhibitory concentration: 1240 nM
For compound 4 the middle estimate is 1.2-fold (0.08 log units) above the measured one, and the stated range covers the measured number.
By their numbers in this assay, from the lowest: compounds 1, 3, 2 and 4 (each within the scatter of the next, the first and the last beyond it).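

With the 4-methylpiperidin-1-yl chain in place, 2-bromophenyl on the aromatic nitrogen instead of 4-fluorophenyl gives a 1.9-fold higher number from compound 3 to compound 4 (0.27 log units; within the scatter) in this assay, so this position carries the bromine-bearing ring with no change that can be told from repeat scatter. Within the data shown here, the only earlier step at this nitrogen, a 2.3-fold higher number from compound 1 to compound 2 (0.36 log units; beyond the scatter) with 2-fluorophenyl on the 4-methylpiperazin-1-yl chain, lay beyond the scatter, but the two steps differ in both halogen and chain and cannot be set directly against each other. Nothing measured here accounts for either step.

The compounds shown leave open how 2-bromophenyl behaves with the 4-methylpiperazin-1-yl chain and how 2-fluorophenyl behaves with the 4-methylpiperidin-1-yl chain. They also leave open whether an unsubstituted phenyl or a 2-chlorophenyl at this nitrogen would give a comparable number.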